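Swapping the Aryl Group at the Saturated Ring Carbon

The source may report more compounds than this note shows. Statements on the series, on what has been measured and on what is new or still open speak of the compounds shown alone.

Of the compounds shown here, three built on one shared core have been measured in a functional assay on Ehrlich cells (Mus musculus) for cytotoxicity, tested at 50 ug/mL; on this read-out lower numbers stand for a weaker effect and higher numbers for a stronger effect at the one concentration tested. Compound 1 `COc1cc(N2C(N)=C(C#N)C(c3ccc([N+](=O)[O-])cc3)C3=C2CC(C)(C)CC3=O)cc(OC)c1OC` gives 70%. Compound 2 `COc1cc(N2C(N)=C(C#N)C(c3c(OC)ccc4ccccc34)C3=C2CC(C)(C)CC3=O)cc(OC)c1OC` gives 10%, and compound 3 `COc1cc(N2C(N)=C(C#N)C(c3c(O)ccc4ccccc34)C3=C2CC(C)(C)CC3=O)cc(OC)c1OC` gives 15%. Compound 2 stands lowest of the three numbers: the nearest is that of compound 3, with a number 5 percentage points higher from compound 2 to compound 3 (within the scatter), a difference within the scatter, while the furthest is that of compound 1, with a number 60 percentage points lower from compound 1 to compound 2 (beyond the scatter), well beyond it.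

Compound 4 `COc1cc(N2C(N)=C(C#N)C(c3ccccc3Cl)C3=C2CC(C)(C)CC3=O)cc(OC)c1OC` has not yet been measured in this assay. It differs from compound 2 in one place: 2-chlorophenyl in place of 2-methoxynaphthalen-1-yl on a saturated ring carbon. The measured steps that bear on this change are the two that exchanged the 4-nitrophenyl group of compound 1 on the same saturated ring carbon, namely a number 60 percentage points lower from compound 1 to compound 2 (beyond the scatter) and a number 55 percentage points lower from compound 1 to compound 3 (beyond the scatter), both large. For the measured compounds named here, compound 4 returns to a single aromatic ring at that carbon, as in compound 1, yet no measured compound carries a 2-chlorophenyl group, so the size of any return is uncertain. A rise from the low number of compound 2, of moderate size, is expected. Compound 4 is therefore estimated to give 45%, within a range from 15% to 75%. The step that this estimate means is a number 35 percentage points higher from compound 2 to compound 4 (beyond the scatter).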

Compound 4, a percentage reported as activity, at one concentration (the size of the read-out at that concentration, not a potency): 20%
For compound 4 the middle estimate is 25 percentage points above the measured one; measured number inside the range.
By their numbers in this assay, from the lowest: compounds 2, 3 and 4 (each within the scatter of the next); then compound 1.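

For the compounds shown here, the new result separates two things that the earlier compounds left joined, the number of aromatic rings at the saturated ring carbon and the identity of the group there. In this assay, the single ring of 2-chlorophenyl does not set compound 4 apart from the two naphthalene compounds, with a number 10 percentage points higher from compound 2 to compound 4 (within the scatter) and a number 5 percentage points higher from compound 3 to compound 4 (within the scatter), whereas a number 50 percentage points lower from compound 1 to compound 4 (beyond the scatter) shows that a single aromatic ring does not by itself bring the number back to that of compound 1. Among these four compounds, the high number therefore goes with the 4-nitrophenyl group of compound 1 and not with the presence of one ring in place of two; nothing shown here explains why this is so.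

As far as these compounds go, it remains open whether the number of compound 1 depends on the nitro group itself or on where that group sits on the phenyl ring. Unsubstituted phenyl, 4-chlorophenyl and 2-nitrophenyl at the same saturated ring carbon would separate these readings, since each changes only part of what distinguishes compound 1 from compound 4.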